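Working notes: from compound 3 to compound 4

The source may report more compounds than this note shows. Statements on the series, on what has been measured and on what is new or still open speak of the compounds shown alone.

Measured in an ADME assay on J774 cells (Mus musculus) for cytotoxicity, read by fluorescence and resazurin assay, with a stated time of 24 h; on this read-out lower numbers stand for higher toxicity in this test and higher numbers for lower toxicity in this test
- compound 1 `O=S(=O)(Nc1nccc2ccccc12)c1ccccc1` gives >= 300000 nM
- compound 2 `Cc1cc2cc(NS(=O)(=O)c3ccc([N+](=O)[O-])cc3)ccc2[nH]1` gives 132000 nM
- compound 3 `Cc1cc2cc(NS(=O)(=O)c3ccc(Cl)cc3)ccc2[nH]1` gives 195000 nM

Compound 1 has the entry >= 300000 nM, which is a limit and not a number. That leaves two numbers in the set, and the step between them reads a 1.5-fold higher number from compound 2 to compound 3 (0.17 log units; within the scatter), so compound 3 stands level with compound 2 within the scatter. Among the compounds with values here, no measured step connects compound 1 to either of them.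

The next structure is compound 4 `Cc1cc2cc(NS(=O)(=O)c3ccc(F)cc3)ccc2[nH]1`, reached by the change (fluoro in place of chloro on an aromatic carbon). It is fluoro in place of chloro on an aromatic carbon of a six-membered aromatic ring of carbon only, para to a large group, or 4-chlorophenyl to 4-fluorophenyl.

Within the data shown here, only one measured step bears on this change, the exchange of chloro for nitro on an aromatic carbon. Because a 1.5-fold higher number from compound 2 to compound 3 (0.17 log units; within the scatter) stayed within the scatter, no step beyond the scatter is expected in this assay for the exchange of fluoro for chloro. This rests on a single step, so the range is kept wide. The estimated size is a 1.1-fold lower number from compound 3 to compound 4 (0.05 log units; within the scatter), which stays within the scatter. For compound 4 the estimated value is 175000 nM, with an expected range from 95000 nM to 300000 nM as the likely span.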

Compound 4, half-maximal cytotoxic concentration: 40400 nM
Estimate against measurement, compound 4: 4.3-fold (0.64 log units) above, outside the stated range (below it).
By their numbers in this assay, from the lowest: compound 4; then compounds 2 and 3 (each within the scatter of the next). At a limit, above all of these: compound 1.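

In this assay the group on the aromatic carbon para to a large group now moves the read-out beyond the scatter, which chloro in place of nitro had not done. Fluoro in place of chloro gives a 4.8-fold lower number from compound 3 to compound 4 (0.68 log units; beyond the scatter), and fluoro in place of nitro gives a 3.3-fold lower number from compound 2 to compound 4 (0.51 log units; beyond the scatter), so compound 4 stands apart from compounds 2 and 3 and has the lowest number in the set, meaning the highest toxicity in this test. No measurement at hand bears on why a single halogen exchange at this place has this effect.

From the compounds shown here alone, with only nitro, chloro and fluoro at this place, it stays open whether fluoro is an isolated case or part of a wider trend, and a methoxy group, an amine or a carboxylic acid on the same carbon would test that. The entry for compound 1, >= 300000 nM, is a limit and not a number, and that compound differs from the others in more than one place, so it adds nothing to this reading.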